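The compounds below may be only part of what the source reports. "The series", "measured", "known", "first", "only" and "open" are said of these compounds alone.

Working notes on the series. Three members have numbers in a functional assay on A549 cells (Homo sapiens) for inhibition, read by MTT assay, with a stated time of 72 h; a lower number here means a stronger inhibitor, a higher number a weaker inhibitor: compound 1 `Cc1ccc(-c2cc(C(=O)N3CCC4(CC3)CC(=O)c3nn(C(C)(C)C)cc3O4)c3ccccc3n2)cc1` gives 5300 nM, compound 2 `CC(C)(C)n1cc2c(n1)C(=O)CC1(CCN(C(=O)c3cc(-c4ccc(F)cc4)nc4ccccc34)CC1)O2` gives 5770 nM and compound 3 `COc1ccc(-c2cc(C(=O)N3CCC4(CC3)CC(=O)c3nn(C(C)(C)C)cc3O4)c3ccccc3n2)cc1` gives 3740 nM. Compound 3 thus stands level with the other two, since a 1.4-fold lower number from compound 1 to compound 3 (0.15 log units; within the scatter) and a 1.5-fold lower number from compound 2 to compound 3 (0.19 log units; within the scatter) both lie within the scatter.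

Compound 4 `CC(C)(C)n1cc2c(n1)C(=O)CC1(CCN(C(=O)c3cc(-c4ccc(N)cc4)nc4ccccc34)CC1)O2` keeps the shared core and has amino in place of methoxy on an aromatic carbon, the change from 4-methoxyphenyl to 4-aminophenyl: amino in place of methoxy on an aromatic carbon.

All three measured steps fall at this same place, para to a large group. Alongside the two above, a 1.1-fold higher number from compound 1 to compound 2 (0.04 log units; within the scatter) is also within the scatter. Methyl, fluoro and methoxy therefore give no separable difference in this assay, but none of these compounds carries amino, so the evidence is indirect. No shift beyond the scatter is expected in either direction, and the estimated step is a 1.1-fold higher number from compound 3 to compound 4 (0.03 log units; within the scatter). For compound 4 the expected value is 4000 nM, with an estimated range of 1500 nM to 9000 nM.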

Compound 4, half-maximal inhibitory concentration: 970 nM
Compound 4: middle estimate off by 4.1-fold (0.62 log units), on the high side; the measured number lies below the stated range.
By their numbers in this assay, from the lowest: compound 4; then compounds 3, 1 and 2 (each within the scatter of the next).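

In this assay, among these compounds, amino is the first group at this place, para to a large group, to separate from the others: a 3.9-fold lower number from compound 3 to compound 4 (0.59 log units; beyond the scatter), alongside a 5.5-fold lower number from compound 1 to compound 4 (0.74 log units; beyond the scatter) and a 5.9-fold lower number from compound 2 to compound 4 (0.77 log units; beyond the scatter). The position therefore responds to the choice of group, which methyl, fluoro and methoxy alone did not reveal, and the change from methoxy to amino also replaces a group with no hydrogen-bond donor by one with a hydrogen-bond donor. Nothing available explains this step, and the donor count remains an observation rather than a cause.

On these data alone, it remains open whether a hydroxyl, a methylamino or a dimethylamino group at this place would track with amino or with the other three groups. The compounds shown also leave open whether the step holds in any cell line other than this one.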